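A Mirror Carbon on the Fluorocyclopropyl Amide

A few compounds are considered here, and "the series" means these few. Any claim that something is new, unique, unknown or untested is made for them only; others in the source may bear on it.

Three amides share one core. Compound 1 `CCCC(=O)N1CC2CC(C1)N2` carries a propyl group on the carbonyl carbon, and in an assay on SH-EP1 cells for agonist activity at Neuronal acetylcholine receptor; alpha4/beta2 (Homo sapiens), read by FLIPR and calcium flux (on this read-out lower numbers stand for smaller maximal responses and higher numbers for larger maximal responses), compound 1 gives 110%. Compound 2 `O=C(C1CCC1)N1CC2CC(C1)N2` has cyclobutyl in place of propyl, and in this assay compound 2 gives 99%, which is a number 11 percentage points lower from compound 1 to compound 2 (beyond the scatter). Compound 3 `O=C([C@H]1C[C@H]1F)N1CC2CC(C1)N2` carries 2-fluorocyclopropyl on the carbonyl carbon, and in this assay compound 3 gives 110%; that is no change at the digits printed from compound 1 to compound 3 (within the scatter) and a number 11 percentage points higher from compound 2 to compound 3 (beyond the scatter). Compound 3 thus stands level with compound 1 at the digits shown, the two together the highest of the three numbers, with compound 2 the furthest away.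

Compound 4 `O=C([C@@H]1C[C@H]1F)N1CC2CC(C1)N2` differs from compound 3 only in the drawn configuration: the two compounds have the same atoms and bonds; at least one stereo element is drawn with a configuration in one of them and without one in the other: 1 of 4 stereo elements differ; a stereocentre at a saturated ring carbon is drawn R in compound 3 and S in compound 4. None of the three measured steps turned a stereocentre; each exchanged one group on the carbonyl carbon for another, and even those exchanges moved the maximal response by at most a modest amount. Within the data shown here, with no stereochemical step on record, the best guide is the narrow band in which all three measured responses sit. The account therefore expects a step of a number 5 percentage points lower from compound 3 to compound 4 (within the scatter), within the scatter. The estimate for compound 4 in this assay is 105%, with a range from 88% to 122%.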

Compound 4, largest response reached (Emax), in percent of the reference or control that the assay uses: 110%
For compound 4 the middle estimate is 5 percentage points below the measured one; the measured number falls inside the stated range.
By their numbers in this assay, from the lowest: compound 2; then compounds 1, 3 and 4 (each within the scatter of the next).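

Turning the stereocentre at the saturated ring carbon, drawn R in compound 3 and S in compound 4, gives in this assay no change at the digits printed from compound 3 to compound 4 (within the scatter), so the maximal response on this read-out does not tell the two drawings apart, something the earlier steps, which only exchanged groups on the carbonyl carbon, could not show. The second drawing of the 2-fluorocyclopropyl amide also matches the first against the other two amides, with a number 11 percentage points higher from compound 2 to compound 4 (beyond the scatter) and no change at the digits printed from compound 1 to compound 4 (within the scatter), so the gap to the cyclobutyl amide does not depend on which of the two drawings is used. This reading has one limit, since the comparison is not one between two fully defined forms: the fact that one of compounds 3 and 4 is drawn with a defined configuration and the other without, at the place where they differ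

As far as these compounds go, it remains open whether the response would hold with a chlorine or a hydroxyl group in place of the fluorine on the cyclopropyl ring, or with a longer chain such as pentyl in place of propyl on the carbonyl carbon. From the compounds shown here alone, it also remains open whether turning the other ring stereocentre of the 2-fluorocyclopropyl group would leave the response just as level.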